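A Piperazine in Place of a Piperidine on the Core

A few compounds are considered here, and "the series" means these few. Any claim that something is new, unique, unknown or untested is made for them only; others in the source may bear on it.

Compound 1, `Nc1ccccc1NC(=O)c1ccc(Cn2cnc3c(NCc4ccccc4)nc(Cl)nc32)cc1`, gives 62.8% in a functional assay on HepG2 cells (Homo sapiens) for antiproliferative activity, read by CCK-8 assay, with a stated time of 72 h, tested at 8 uM; a higher number here means a stronger effect of the compound at the concentration tested, a lower number a weaker effect.
Compound 2, `Nc1ccccc1NC(=O)c1ccc(Cn2cnc3c(Nc4cccc(OC(F)(F)F)c4)nc(Cl)nc32)cc1`, gives 31.2% in this assay.
Compound 3, `CC1CCN(c2nc(Cl)nc3c2ncn3Cc2ccc(C(=O)Nc3ccccc3N)cc2)CC1`, gives 65.3% in this assay.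

Compound 3 carries the largest of the three numbers shown, but the step of a number 2.5 percentage points higher from compound 1 to compound 3 (within the scatter) lies within the scatter, so compound 3 and compound 1 cannot be told apart. Only compound 2 stands clearly apart: the step of a number 34.1 percentage points higher from compound 2 to compound 3 (beyond the scatter) is large, as is the step of a number 31.6 percentage points lower from compound 1 to compound 2 (beyond the scatter).

Compound 4, `CN1CCN(c2nc(Cl)nc3c2ncn3Cc2ccc(C(=O)Nc3ccccc3N)cc2)CC1`, differs from compound 3 in one place: 4-methylpiperazin-1-yl in place of 4-methylpiperidin-1-yl on an aromatic carbon. Within the data shown here, no measured step exchanges one saturated ring for another on this carbon. The step of a number 2.5 percentage points higher from compound 1 to compound 3 (within the scatter), which brought the 4-methylpiperidin-1-yl group in for benzylamino, stayed within the scatter; the two large steps both involve the (3-(trifluoromethoxy)phenyl)amino group of compound 2 and do not bear on a ring-for-ring exchange. The expectation for compound 4 in this assay is therefore a step of no more than the scatter, a number 7.3 percentage points lower from compound 3 to compound 4 (within the scatter). Compound 4 is estimated at 58% in this assay, expected to fall between 40% and 75%.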

Compound 4, a percentage reported as inhibition, at one concentration (the size of the read-out at that concentration, not a potency): 75%
Estimate against measurement, compound 4: 17 percentage points below; measured number inside the range.
By their numbers in this assay, from the lowest: compound 2; then compounds 1, 3 and 4 (each within the scatter of the next, the first and the last beyond it).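

Exchanging one saturated ring for another on this aromatic carbon, with 4-methylpiperazin-1-yl in place of 4-methylpiperidin-1-yl, gives a number 9.7 percentage points higher from compound 3 to compound 4 (within the scatter) in this assay, so the second ring nitrogen leaves the read-out within the scatter of the piperidine. Even so, compound 4 is the first ring-bearing compound set apart from the benzylamino compound, with a number 12.2 percentage points higher from compound 1 to compound 4 (beyond the scatter), a modest step where compound 3 could not be told from compound 1, while the distance from the (3-(trifluoromethoxy)phenyl)amino compound grows to a large step, a number 43.8 percentage points higher from compound 2 to compound 4 (beyond the scatter). No measurement given here accounts for any of these steps, so the data offer no explanation of them.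

The compounds shown leave open whether the read-out at this carbon depends on the methyl group on the piperazine nitrogen, as a piperazin-1-yl ring with a hydrogen there, an acetyl group or a longer chain, or a morpholin-4-yl ring, would show. They also leave open whether the chloro group on the shared core matters to these steps, and how the compounds compare as potencies, since each number is a read-out at a single concentration.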